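The source may hold more compounds than are shown below. What is called first, only, known or untested is meant among the compounds shown, and "the series" means these compounds.

In a functional assay on KBVIN cells (Homo sapiens) for antiproliferative activity, read by sulforhodamine B assay, with a stated time of 3 days (a lower number here means that less compound is needed, a higher number that more compound is needed for the effect), three compounds have been measured:

Compound 1 `CCC1=C(O)c2c(oc(-c3ccc(C)cc3)cc2=O)C(CC)(CC)C1=O` gives 0.08 uM
Compound 2 `CCC1=C(O)c2c(oc(-c3ccc(Br)cc3)cc2=O)C(CC)(CC)C1=O` gives 15.7 uM
Compound 3 `CCC1=C(O)c2c(oc(-c3ccc(C)cc3C)cc2=O)C(CC)(CC)C1=O` gives 8.52 uM

All three share one core and differ only in the substituted phenyl group it carries. Compound 3 is one of two compounds at the high end of these numbers, and those two cannot be told apart (a 1.8-fold lower number from compound 2 to compound 3 (0.27 log units; within the scatter)). Compound 1 stands alone at the low end, and the swap of its methyl for bromo is a large step (a 200-fold higher number from compound 1 to compound 2 (2.29 log units; beyond the scatter)).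

Compound 4 `CCC1=C(O)c2c(oc(-c3cc(C)c(C)cc3C)cc2=O)C(CC)(CC)C1=O` turns the 2,4-dimethylphenyl of compound 3 into 2,4,5-trimethylphenyl. This puts methyl in place of hydrogen on an aromatic carbon, ortho to a methyl group and para to a methyl group (methyl in place of hydrogen on an aromatic carbon).

For the measured compounds named here, only one measured step is of this same kind, and it was large and upward (a 110-fold higher number from compound 1 to compound 3 (2.03 log units; beyond the scatter)). It began from compound 1, however, and no data show what a further methyl does once a compound already sits at the high end. A large upward step is therefore possible but not the likeliest outcome, and a return to the low end seems unlikely. The expected change is small and within the scatter (a 1.2-fold higher number from compound 3 to compound 4 (0.07 log units; within the scatter)). Compound 4 is estimated at 10 uM with an expected range of 3 uM to 35 uM around that figure.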

Compound 4, concentration for half-maximal effect: 4.37 uM
The estimate for compound 4 lay 2.3-fold (0.36 log units) above the measured number, and the stated range covers the measured number.
By their numbers in this assay, from the lowest: compound 1; then compounds 4, 3 and 2 (each within the scatter of the next, the first and the last beyond it).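

In this assay, compound 4 cannot be told apart from compound 3 (a 1.9-fold lower number from compound 3 to compound 4 (0.29 log units; within the scatter)), so the further methyl, ortho to a methyl group and para to a methyl group, does not repeat the large step seen between compound 1 and compound 3. Compound 4 does separate from the 4-bromophenyl compound, though only modestly (a 3.6-fold lower number from compound 2 to compound 4 (0.56 log units; beyond the scatter)), whereas compound 3 stayed within the scatter of that compound, and the gap to the 4-methylphenyl compound remains large (a 55-fold higher number from compound 1 to compound 4 (1.74 log units; beyond the scatter)), so this methyl brings no return to the low end. Nothing available here explains why the numbers fall this way.

As far as these compounds go, how an amine, a carboxylic acid or a longer chain such as propyl would read at this same place on the ring remains open. For the compounds shown here, also open is what this methyl does on a ring without the other two methyl groups: here it is seen only on the 2,4-dimethylphenyl group, so its effect elsewhere cannot be judged.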